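One Aryl Ring Changed on Compound 1

The source may report more compounds than this note shows. Statements on the series, on what has been measured and on what is new or still open speak of the compounds shown alone.

Compound 1, `COc1cc(NC(=O)Nc2cc(Nc3ccc(F)c(Cl)c3)ncn2)cc(OC)c1`: 77.5%
Compound 2, `COc1ccc(OC)c(Nc2cc(NC(=O)Nc3c(Cl)cccc3Cl)ncn2)c1`: 95%

Both were tested in a functional assay on PC-9 cells (Homo sapiens) for inhibition, read by MTT assay, with a stated time of 48 h, tested at 10 uM; a lower number here means less inhibition, a higher number more inhibition at the concentration tested (going by the name of the read-out). Compound 1 stands lowest of the two numbers; compound 2 lies higher by a gap beyond the usual scatter. Compound 3, `COc1cc(NC(=O)Nc2cc(Nc3ccc(OC)c(I)c3)ncn2)cc(OC)c1`, has not been measured. It differs from compound 1 in one place: 3-iodo-4-methoxyphenyl in place of 3-chloro-4-fluorophenyl on a nitrogen on an aromatic ring. Among the compounds with values here, no measured pair shows a change of this kind, so the size of its effect is unknown. The step from compound 1 to compound 3 is expected to be small, a number 2.5 percentage points lower from compound 1 to compound 3 (within the scatter), with either direction possible and likely within the scatter. Compound 3 is estimated at 75%, ranging from 55% to 92%.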

Compound 3, a percentage reported as inhibition, at one concentration (the size of the read-out at that concentration, not a potency): 47.1%
Compound 3: the middle estimate sits 27.9 percentage points above what was measured; measured number outside the range, below it.
By their numbers in this assay, from the lowest: compound 3; then compound 1; then compound 2.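

In this assay, the group on this nitrogen matters: 3-iodo-4-methoxyphenyl in place of 3-chloro-4-fluorophenyl gives a number 30.4 percentage points lower from compound 1 to compound 3 (beyond the scatter). Within the data shown here, this is the first change made in one place only, so this swap alone accounts for the loss of inhibition, which the two earlier compounds could not show. Nothing available explains the drop.

Going by these compounds, the iodine and the methoxy enter together, so their separate shares stay open. Also open, on these data alone, is how an amine or a carboxylic acid on this aryl ring would fare.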